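Swapping the aryl group on the piperazine of compound 1

A few compounds are considered here, and "the series" means these few. Any claim that something is new, unique, unknown or untested is made for them only; others in the source may bear on it.

Compound 1 `CCOc1ccccc1N1CCN(CCCNc2ncccc2C(=O)N(C)C)CC1` is measured in a functional assay on aorta for antagonist activity at Alpha-1D adrenergic receptor (Rattus norvegicus) (on this read-out lower numbers stand for tighter binding and higher numbers for weaker binding), where compound 1 gives 7.94 nM. Among the measured compounds shown here, its only measured neighbour is compound 2 `CN(C)C(=O)c1cccnc1NCCCN1CCN(c2ccccc2OCC2CC2)CC1`, which in this assay gives 10 nM; the step of a 1.3-fold higher number from compound 1 to compound 2 (0.10 log units; within the scatter) keeps the two side by side. Compound 3 `COc1cc(C)ccc1N1CCN(CCCNc2ncccc2C(=O)N(C)C)CC1` differs from compound 1 by 2-methoxy-4-methylphenyl in place of 2-ethoxyphenyl on an amine nitrogen in a ring. For the measured compounds named here, no measured step touches this part of the core; the single known step changes a different group and stays within the scatter, so no shift beyond the scatter is expected. Compound 3 is estimated at 10 nM, with a range from 3 nM to 32 nM. The expected step is a 1.3-fold higher number from compound 1 to compound 3 (0.10 log units; within the scatter).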

Compound 3, dissociation constant: 39.8 nM
Compound 3: the middle estimate sits 4.0-fold (0.60 log units) below what was measured; the whole stated range lies below it.
By their numbers in this assay, from the lowest: compounds 1 and 2 (each within the scatter of the next); then compound 3.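

In this assay, putting 2-methoxy-4-methylphenyl in place of 2-ethoxyphenyl on an amine nitrogen in a ring gives a 5.0-fold higher number from compound 1 to compound 3 (0.70 log units; beyond the scatter). This aryl group therefore responds to a swap that leaves its heavy-atom and acceptor counts unchanged, whereas the earlier change, a 1.3-fold higher number from compound 1 to compound 2 (0.10 log units; within the scatter), did not move the number beyond the scatter. Nothing available explains this shift.

As far as these compounds go, the swap shortens the ether chain and adds a ring methyl at once, so their separate contributions remain open. Values for 2-methoxyphenyl or 2-ethoxy-4-methylphenyl would separate them.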